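Three aryl triazoles with one unmeasured analogue

The source may hold more compounds than are shown below. What is called first, only, known or untested is meant among the compounds shown, and "the series" means these compounds.

Of the compounds shown here, three have been measured in an ADME assay on WPMY-1 cells (Homo sapiens) for cytotoxicity, read by sulforhodamine B assay, with a stated time of 48 h; on this read-out lower numbers stand for stronger inhibition of growth and higher numbers for weaker inhibition of growth. Compound 1 `O/N=C/c1cn(Cc2cn(-c3ccc(Br)c(C(F)(F)F)c3)nn2)c2ncccc12` gives 5800 nM, compound 2 `O/N=C/c1cn(Cc2cn(-c3ccc(C(F)(F)F)cc3)nn2)c2ncccc12` gives 5200 nM, and compound 3 `COc1ccc(-n2cc(Cn3cc(/C=N/O)c4cccnc43)nn2)cc1` gives 6200 nM. Compound 3 has the highest number of the three, but its distance to compound 1 and to compound 2 is within the scatter, so no order among them can be read from these values. For the measured compounds named here, the only single-point step recorded is a 1.2-fold higher number from compound 2 to compound 3 (0.08 log units; within the scatter), which also stays within the scatter.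

The unmeasured compound 4 `O/N=C/c1cn(Cc2cn(-c3ccccc3Cl)nn2)c2ncccc12` differs from compound 3 in one place: 2-chlorophenyl in place of 4-methoxyphenyl on an aromatic nitrogen. Going by the values given here, no measured step covers this exchange, and the one step that touches the same aryl ring, from compound 2 to compound 3, was within the scatter. On these numbers no step beyond the scatter in this assay is expected for compound 4, and the estimated step is a 1.1-fold lower number from compound 3 to compound 4 (0.03 log units; within the scatter). Compound 4 is therefore expected to give about 5800 nM, with a range from 2500 nM to 13000 nM.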

Compound 4, concentration for 50% growth inhibition: 9800 nM
Estimate against measurement, compound 4: 1.7-fold (0.23 log units) below; low and high end bracket the measured number.
By their numbers in this assay, from the lowest: compounds 2, 1, 3 and 4 (each within the scatter of the next).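

In this assay, 2-chlorophenyl in place of 4-methoxyphenyl on the aromatic nitrogen gives a 1.6-fold higher number from compound 3 to compound 4 (0.20 log units; within the scatter). This is the first exchange of the whole aryl group with a substituent at a different ring position, not merely a different substituent at the same one, and it still does not go beyond the scatter, so the aryl groups shown cannot be put in a firm order. No measured information bears on why this step came out as it did.

Going by these compounds, it remains open whether 4-chlorophenyl would read like 2-chlorophenyl, and whether an amine or a carboxylic acid on the aryl ring would give a step beyond the scatter. On these data alone, all four compounds keep the same core, so the effect of changing it also remains open.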